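This account rests on a few compounds, and the source may have more. Where it says the series, first, only, none or still open, it means among the compounds named here.

Compound 1 `O=c1[nH]c(SCc2ccccc2)nc2ccccc12` gives > 64000 nM
Compound 2 `O=c1[nH]c(SCc2cccs2)nc2ccccc12` gives > 64000 nM
Compound 3 `O=c1[nH]c(SCc2ccc(-c3ccccc3)cc2)nc2ccccc12` gives > 64000 nM

These three results come from an ADME assay on MRC5 cells (Homo sapiens) for cytotoxicity, read by neutral red uptake (a higher number here means that more compound is tolerated, a lower number that less compound is tolerated), and each is a limit of the assay rather than a number. Compound 3 stands at the limit of > 64000 nM in this assay, at which 3 of the 3 values shown sit, and so has no exact value to start from.

Compound 4 `COc1ccc(CSc2nc3ccccc3c(=O)[nH]2)cc1` carries methoxy in place of phenyl on an aromatic carbon. For the measured compounds named here, two measured steps bear on this change (a step that the two limits leave unreadable from compound 1 to compound 2) and (a step that the two limits leave unreadable from compound 1 to compound 3), and neither has a readable size. The second is the closer guide, since it also concerns a phenyl on an aromatic carbon. Going by the values given here, with no size to carry over, the only guide is that all three measured compounds sit at the limit. No change beyond the usual scatter is therefore expected in this assay, in either direction, and the expected step is small (a number no higher from compound 3 to compound 4 (the limit leaves the size open)). Compound 4 is estimated at 64000 nM (expected range 35000 nM to 90000 nM).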

Compound 4, half-maximal cytotoxic concentration: > 64000 nM
Compound 4: a limit, no number; the forecaster's own chance of this, stated with the estimate: 85%; the middle value sits exactly at the limit.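

For the compounds shown here, compound 4 gives only a limit, as do compound 1 and compound 3, so neither the step from compound 3 to compound 4 nor the one from compound 1 to compound 4 can be read. The compounds shown leave open at what concentration any of them would become toxic in this assay, because all of them share one reading: the limit of > 64000 nM in this assay, at which 4 of the 4 values shown sit.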